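Small change to compound 2, solubility still open

The source may hold more compounds than are shown below. What is called first, only, known or untested is meant among the compounds shown, and "the series" means these compounds.

Measured so far in a physicochemical assay for solubility, at pH 7.4; on this read-out higher numbers stand for higher solubility and lower numbers for lower solubility:
compound 1 (`C[C@H]1[C@H](N)CN1c1c(F)cc2c(=O)c(C(=O)O)cn(-c3ccc(F)cc3)c2c1F`) gives 11.2 ug/mL
compound 2 (`C[C@H]1N(c2c(F)cc3c(=O)c(C(=O)O)cn(C4CC4)c3c2F)C[C@]1(C)N`) gives 3.3 ug/mL

Compound 2 has the lower of these two numbers, and the gap to compound 1 lies beyond the usual scatter of repeated measurements. The next compound to be measured is compound 3 (`C[C@H]1[C@H](N)CN1c1c(F)cc2c(=O)c(C(=O)O)cn(C3CC3)c2c1F`), which differs from compound 2 in one place. That change is a group of 6 heavy atoms (4 carbon, 2 nitrogen; one four-membered non-aromatic ring with 1 hetero atom) in place of a group of 7 heavy atoms (5 carbon, 2 nitrogen; one four-membered non-aromatic ring with 1 hetero atom), on an aromatic carbon and it sits on an aromatic carbon, ortho to two fluoro groups. In short, a group of 6 heavy atoms replaces a group of 7 heavy atoms, and both groups contain one four-membered non-aromatic ring with 1 hetero atom.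

Among the compounds with values here, no two measured compounds differ in only one place, so no measured step shows the effect of this change in this assay on its own. The entering group also sits on compound 1 (11.2 ug/mL) but that compound differs elsewhere too, which makes it only a weak guide. A small rise within the scatter is therefore expected, and the estimated step is a 1.7-fold higher number from compound 2 to compound 3 (0.22 log units; within the scatter) in size. For compound 3 the expected value is 5.5 ug/mL (estimated range 2.2 ug/mL to 14 ug/mL).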

Compound 3, solubility: 23.2 ug/mL
Compound 3: the middle estimate sits 4.2-fold (0.63 log units) below what was measured; the whole stated range lies below it.
By their numbers in this assay, from the lowest: compound 2; then compound 1; then compound 3.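

In this assay the aromatic carbon ortho to two fluoro groups proves responsive to a very small edit: placing the group of 6 heavy atoms (4 carbon, 2 nitrogen) there instead of the group of 7 heavy atoms (5 carbon, 2 nitrogen) gives a 7.0-fold higher number from compound 2 to compound 3 (0.85 log units; beyond the scatter) even though both groups keep one four-membered non-aromatic ring. The aromatic nitrogen matters as well, since cyclopropyl in place of 4-fluorophenyl gives a 2.1-fold higher number from compound 1 to compound 3 (0.32 log units; beyond the scatter) with the rest of the molecule unchanged, and this step also lies beyond the usual scatter. No measurement shown here accounts for either rise, so the reason for them remains unknown.

On these data alone, each change has been seen only once, against a single background, so it remains open whether the same swap on the aromatic carbon would give a similar step with 4-fluorophenyl on the aromatic nitrogen. Also open, as far as these compounds go, is how a piperazine or a pyrrolidine on that aromatic carbon, or an ethyl group on the aromatic nitrogen, would compare with compound 3 on this read-out.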